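From Oxane to Sulfone: A Single Ring Change

This account rests on a few compounds, and the source may have more. Where it says the series, first, only, none or still open, it means among the compounds named here.

Compound 1 `NC(=O)[C@H]1CN(c2ccc(C3CCOCC3)c(F)c2)C(=O)O1` was tested in an assay on isolated protein for inhibition of Amine oxidase [flavin-containing] A (Homo sapiens) (a lower number here means a stronger inhibitor, a higher number a weaker inhibitor), and gave 58000 nM. For the measured compounds named here, that is the lower of the two numbers measured so far. Going by the values given here, the only other measured compound, compound 2 `NC(=O)[C@H]1CN(c2cc(F)c(C3CC[S+]([O-])CC3)c(F)c2)C(=O)O1`, gives 355000 nM in this assay, a gap well beyond the usual scatter; the two compounds differ in more than one place at once, so that gap cannot be tied to any single change.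

Compound 3 `NC(=O)[C@H]1CN(c2ccc(C3CCS(=O)(=O)CC3)c(F)c2)C(=O)O1` has not yet been measured. It differs from compound 1 in one place: 1,1-dioxothian-4-yl in place of oxan-4-yl on an aromatic carbon. Among the compounds with values here, no measured pair shows this exact exchange, so the expectation rests on the two numbers above and on compound 1 already being a weak inhibitor. A step from compound 1 to compound 3 of a 1.9-fold higher number from compound 1 to compound 3 (0.28 log units; within the scatter) is expected, a modest move toward a weaker number that could also turn out to lie within the scatter. For compound 3 an inhibition constant near 110000 nM is estimated, with a range from 35000 nM to 350000 nM.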

Compound 3, inhibition constant: 105000 nM
Beside the measured number, compound 3's estimate is 1.0-fold (0.02 log units) above it, within the range that was stated.
By their numbers in this assay, from the lowest: compounds 1 and 3 (each within the scatter of the next); then compound 2.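

In this assay, for the compounds shown here, putting 1,1-dioxothian-4-yl in place of oxan-4-yl on an aromatic carbon gives a 1.8-fold higher number from compound 1 to compound 3 (0.26 log units; within the scatter), which is the first exchange at this position that can be read on its own. The ring that enters carries more heavy atoms and more hydrogen-bond acceptors than the one that leaves, yet this assay cannot tell compound 1 and compound 3 apart, so at this position, for these two rings, that difference in make-up does not show up in the inhibition constant. No other measurement bears on this result, so the data offer no explanation of why the two rings read alike.

On these data alone, with only these two rings compared at this position, it remains open whether a group of another kind there, such as a ring carrying an amine or a carboxylic acid, would move the number beyond the scatter. As far as these compounds go, it is equally open whether an open chain, such as a methoxyethyl group, could stand in place of the ring without a change that the assay can detect.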